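This account rests on a few compounds, and the source may have more. Where it says the series, first, only, none or still open, it means among the compounds named here.

Two compounds of this series carry a measured value in a functional assay on MKN-45 cells (Homo sapiens) for cytotoxicity, read by MTT assay, with a stated time of 72 h; a lower number here means a stronger inhibitor, a higher number a weaker inhibitor. Compound 1, with the structure `CN(C)CCCNc1nc(-c2ccc(NC(=O)Nc3ccc(Cl)cc3Cl)cc2)nc2c(Cl)c(Cl)sc12`, gives 2560 nM in this assay. Compound 2, with the structure `CCN(CC)CCCNc1nc(-c2ccc(NC(=O)Nc3ccc(Cl)cc3)cc2)nc2c(Cl)c(Cl)sc12`, gives 720 nM in this assay, the lowest of the two numbers recorded; the gap to compound 1 lies beyond the usual scatter. Compound 1 and compound 2 differ in two places at once, so the two values alone cannot be split between those changes.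

Compound 3, with the structure `CCN(CC)CCCNc1nc(-c2ccc(NC(=O)Nc3ccc(Cl)cc3Cl)cc2)nc2c(Cl)c(Cl)sc12`, has not yet been measured. It differs from compound 2 in one place: chloro in place of hydrogen on an aromatic carbon, in words, chloro in place of hydrogen on an aromatic carbon, so that the 4-chlorophenyl becomes a 2,4-dichlorophenyl. Compound 3 thereby comes to carry the same urea aryl group as compound 1, while keeping the diethylamino chain of compound 2. Compound 1 is the weaker of the two measured compounds, so in this assay the step of a 2.5-fold higher number from compound 2 to compound 3 (0.40 log units; beyond the scatter) is expected to run toward a higher number. Compound 3 is accordingly estimated at 1800 nM, within a range from 700 nM to 4500 nM.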

Compound 3, half-maximal inhibitory concentration: 5720 nM
For compound 3 the middle estimate is 3.2-fold (0.50 log units) below the measured one; measured number above the stated range.
By their numbers in this assay, from the lowest: compound 2; then compound 1; then compound 3.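

In this assay, the change from 4-chlorophenyl to 2,4-dichlorophenyl can now be read on its own, and this added chloro on the aromatic carbon gives a weaker inhibitor (a 7.9-fold higher number from compound 2 to compound 3 (0.90 log units; beyond the scatter)). With the 2,4-dichlorophenyl held fixed, diethylamino in place of dimethylamino also runs toward a weaker inhibitor (a 2.2-fold higher number from compound 1 to compound 3 (0.35 log units; beyond the scatter)), so the two changes that separate compound 1 from compound 2 can now be read apart, and compound 3, which carries both the added chloro and the diethylamino group, is the weakest of the three. No measurement here bears on why either change has this effect.

The compounds shown leave open whether the added chloro would cost as much on a dimethylamino chain, and whether the diethylamino step would hold with a 4-chlorophenyl on the urea. They also leave open how fluoro, methyl or methoxy would compare at the same aromatic carbon, and how a pyrrolidine or morpholine would compare at the end of the chain.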